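Working notes: bromo in place of acetyl

The source may report more compounds than this note shows. Statements on the series, on what has been measured and on what is new or still open speak of the compounds shown alone.

Measured so far:
- compound 1 `Cc1ccccc1C(=O)Nc1nc(-c2ccccn2)cs1`: 6300 nM
- compound 2 `CC(=O)c1cccc(C(=O)Nc2nc(-c3ccccn3)cs2)c1`: 1500 nM

Both values come from an ADME assay on Vero cells (Chlorocebus sabaeus) for cytotoxicity, read by MTT assay, with a stated time of 72 h; a higher number here means that more compound is needed for the effect, a lower number that less compound is needed. In this assay compound 2 has the lower of the two numbers at 1500 nM, and the gap to compound 1, which gives 6300 nM, lies beyond the usual scatter of repeated measurements.

The next compound is compound 3 `O=C(Nc1nc(-c2ccccn2)cs1)c1cccc(Br)c1`, which has bromo in place of acetyl on an aromatic carbon of compound 2, meta to a large group (bromo in place of acetyl on an aromatic carbon). For the measured compounds named here, no measured pair isolates this change, and compound 1 and compound 2 are only two points, so the expectation is loose. A modest rise in the number in this assay is expected, with a size no greater than the gap between the two measured compounds. The expected change is a 2.1-fold higher number from compound 2 to compound 3 (0.33 log units; beyond the scatter), which would sit near the edge of the scatter. For compound 3 the estimated value is 3200 nM, with an expected range of 1100 nM to 9000 nM.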

Compound 3, half-maximal effective concentration: 16100 nM
Beside the measured number, compound 3's estimate is 5.0-fold (0.70 log units) below it, outside the stated range (above it).
By their numbers in this assay, from the lowest: compound 2; then compound 1; then compound 3.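

In this assay, the place on the six-membered aromatic ring that carries acetyl in compound 2 proves highly sensitive, since bromo in place of acetyl gives an 11-fold higher number from compound 2 to compound 3 (1.03 log units; beyond the scatter) and a single substitution there produces a large change. The other listed comparison, 3-bromophenyl in place of 2-methylphenyl on a carbonyl carbon, gives a 2.6-fold higher number from compound 1 to compound 3 (0.41 log units; beyond the scatter), a modest step that also lies beyond the scatter, so compound 3 has the highest number of the three, above both compound 1 and compound 2. Nothing measured in this set accounts for the size of either step, and the structural counts show only that acetyl brings more heavy atoms and a hydrogen-bond acceptor than bromo does.

As far as these compounds go, it remains open whether the rise belongs to the arrival of bromo or to the departure of acetyl, as one step cannot separate the two. Other groups at this same place, such as a nitrile, a carboxylic acid, an amine or a longer chain, would show whether acetyl stands apart in this series or whether the number varies widely with any replacement.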